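This account rests on a few compounds, and the source may have more. Where it says the series, first, only, none or still open, it means among the compounds named here.

Working notes on the series sharing the core of compound 1 `CN1CCc2nc(C#Cc3ccccc3)sc2C1`. In an assay on HEK293 cells for negative allosteric modulation of metabotropic glutamate receptor 5 (Homo sapiens), read by FLIPR, with a stated time of 1 h (on this read-out higher numbers stand for weaker inhibition and lower numbers for stronger inhibition), compound 1 gives only a limit, > 10000 nM. Compound 2 `CCCCN1CCc2nc(C#Cc3ccccc3)sc2C1` carries a butyl group on the ring nitrogen, and in this assay compound 2 likewise gives only a limit, > 10000 nM. Compound 3 `O=C(C1CCCCC1)N1CCc2nc(C#Cc3ccccc3)sc2C1` bears a cyclohexylcarbonyl group on that nitrogen, and in this assay compound 3 also gives only a limit, > 10000 nM. Compound 3 therefore stands at the same limit as the other two, with no readable position among them; (the limit of > 10000 nM in this assay, at which 3 of the 3 values shown sit).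

The next compound, compound 4 `Cc1nc(C(=O)N2CCc3nc(C#Cc4ccccc4)sc3C2)cs1`, differs from compound 3 by 2-methyl-1,3-thiazol-4-yl in place of cyclohexyl on a carbonyl carbon. Of the measured steps, a step that the two limits leave unreadable from compound 1 to compound 3, a step that the two limits leave unreadable from compound 2 to compound 3 and a step that the two limits leave unreadable from compound 1 to compound 2 all concern the substituent on the ring nitrogen, but each is left unreadable by the limits, so none gives a size or a direction that can be carried over to the step from compound 3 to compound 4. With no readable step to build on, the expectation for compound 4 rests on the shared limit, and compound 4 is estimated to give 8000 nM, within 1500 nM to 10000 nM, meaning an expected step of an at least 1.2-fold lower number from compound 3 to compound 4 (0.09 log units; that floor lies within the scatter), most likely again a limit rather than a number.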

Compound 4, half-maximal inhibitory concentration: > 10000 nM
Compound 4 ended at the assay's limit (the forecaster's own chance of this, stated with the estimate: 65%); middle value at least 1.2-fold (0.09 log units) away from the limit.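

In this assay compound 4 also gives only a limit, so none of its steps from compound 1, compound 2 or compound 3 can be read: the limit of > 10000 nM in this assay, at which 4 of the 4 values shown sit. The compounds shown leave open how these four rank against one another in this assay, and whether any group on the ring nitrogen gives a readable number.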